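Thiophen-3-yl to 1-benzofuran-2-yl: working notes

The source may report more compounds than this note shows. Statements on the series, on what has been measured and on what is new or still open speak of the compounds shown alone.

Values in a functional assay on HepG2 cells (Homo sapiens) for antiproliferative activity, read by XTT assay, with a stated time of 72 h; on this read-out higher numbers stand for weaker inhibition and lower numbers for stronger inhibition:
- compound 1 `CNc1ncnc2c1c(-c1cccs1)cn2[C@@H]1O[C@H](CO)[C@@H](O)[C@H]1O`: > 20000 nM
- compound 2 `CNc1ncnc2c1c(-c1ccsc1)cn2[C@@H]1O[C@H](CO)[C@@H](O)[C@H]1O`: > 20000 nM

Both entries are limits of the assay and not numbers. Compound 2 has only the limit > 20000 nM in this assay. Going by the values given here, the sole other value, for compound 1, is also a limit, so compound 2 cannot be placed against a number.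

The next structure is compound 3 `CNc1ncnc2c1c(-c1cc3ccccc3o1)cn2[C@@H]1O[C@H](CO)[C@@H](O)[C@H]1O`, with 1-benzofuran-2-yl in place of thiophen-3-yl on an aromatic carbon of the shared core: 1-benzofuran-2-yl in place of thiophen-3-yl on an aromatic carbon.

Among the compounds with values here, the only measured step is a step that the two limits leave unreadable from compound 1 to compound 2. It gives no size or direction to carry over to this change. All that the series offers is the limit of > 20000 nM in this assay, at which 2 of the 2 values shown sit. Within the data shown here, a second reading at this limit is therefore the expectation in this assay, with a modest chance of a measurable number, and no step of known size is expected.

Compound 3 is estimated at 20000 nM, with an expected range of 8000 nM to 40000 nM. This estimate means an expected a number no higher from compound 2 to compound 3 (the limit leaves the size open).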

Compound 3, half-maximal inhibitory concentration: > 20000 nM
Compound 3: no number, only a limit (the forecaster's own chance of this, stated with the estimate: 75%); the middle value sits exactly at the limit.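

In this assay compound 3 gives > 20000 nM, which is a limit and not a number. Going by these compounds alone, with compound 1 and compound 2 also at limits, no step to compound 3 can be read. The compounds shown leave open whether any group at this place on the shared core gives a measurable number in this assay, and what size or direction a step there would have.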